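The compounds below may be only part of what the source reports. "The series", "measured", "known", "first", "only" and "open" are said of these compounds alone.

Compound 2, with the structure `COc1cc(-c2cccc3nc(-c4cccc(F)c4)oc23)cc(OC)c1OC`, is the point of departure. In a functional assay on MCF7 cells (Homo sapiens) for antiproliferative activity, read by MTT assay, with a stated time of 48 h (a lower number here means a stronger inhibitor, a higher number a weaker inhibitor), compound 2 gives > 25000 nM, which is a limit of the assay and not a measured number. Compound 1, with the structure `COc1cccc(-c2nc3cccc(-c4cc(OC)c(OC)c(OC)c4)c3o2)c1`, gives > 25000 nM in this assay, again a limit. Compound 3, with the structure `COc1cc(-c2cccc3nc(-c4cccc(Cl)c4)oc23)cc(OC)c1OC`, gives > 25000 nM in this assay, likewise a limit. The change from compound 1 to compound 2 is fluoro in place of methoxy on an aromatic carbon, and its step that the two limits leave unreadable from compound 1 to compound 2 cannot be read; the same holds for a step that the two limits leave unreadable from compound 1 to compound 3 and for a step that the two limits leave unreadable from compound 2 to compound 3, because the limit of > 25000 nM in this assay, at which 3 of the 3 values shown sit, applies to every value shown.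

Compound 4 has the structure `COc1cc(-c2cccc3nc(-c4cccc(C)c4)oc23)cc(OC)c1OC`. The change from compound 2 to compound 4 is methyl in place of fluoro on an aromatic carbon. Among the measured compounds shown here, no measured step bears on this change in a readable way, so no direction can be drawn from the three limits. Compound 4 is therefore expected to give about 30000 nM, within 8000 nM to 120000 nM, most probably again as a limit, meaning an estimated step that the limit leaves unreadable from compound 2 to compound 4.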

Compound 4, half-maximal inhibitory concentration: > 25000 nM
Compound 4 was reported as a limit; the forecaster's own chance of this, stated with the estimate: 80%; the middle value lies beyond the limit too.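

Compound 4 adds no readable step against compound 1, compound 2 or compound 3, because each value is a limit and not a number: the limit of > 25000 nM in this assay, at which 4 of the 4 values shown sit.

The compounds shown leave open whether these groups on the shared core differ at all in this assay.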